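A few compounds are considered here, and "the series" means these few. Any claim that something is new, unique, unknown or untested is made for them only; others in the source may bear on it.

Measured in a functional assay on MIA PaCa-2 cells (Homo sapiens) for cytotoxicity, read by MTT assay, with a stated time of 72 h; on this read-out higher numbers stand for weaker inhibition and lower numbers for stronger inhibition:
- compound 1 `COC1=CC(=O)c2c(COc3ccc(C#N)cc3)c(C)n(C)c2C1=O`: 192 nM
- compound 2 `COC1=CC(=O)c2c(COc3ccc(F)cc3)c(C)n(C)c2C1=O`: 493 nM
- compound 3 `COC1=CC(=O)c2c(COc3ccc(F)cc3F)c(C)n(C)c2C1=O`: 75 nM

Of the three, compound 3 holds the lowest number, 75 nM, and its steps to both others lie beyond the scatter.

Next is compound 4 `COC1=CC(=O)c2c(COc3c(F)cc(F)cc3F)c(C)n(C)c2C1=O`. The change is fluoro in place of hydrogen on an aromatic carbon, ortho to a large group and meta to two fluoro groups.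

Within the data shown here, the closest precedent is the same replacement, which gave a 6.6-fold lower number from compound 2 to compound 3 (0.82 log units; beyond the scatter). This is a single case, so it sets a direction more firmly than a size. The other two steps, a 2.6-fold higher number from compound 1 to compound 2 (0.41 log units; beyond the scatter) and a 2.6-fold lower number from compound 1 to compound 3 (0.41 log units; beyond the scatter), show that this assay responds to changes in substitution on this aromatic ring, with sizes smaller than the precedent.

A smaller step than the precedent is therefore expected, toward a lower number, and it may not clear the scatter. The estimated step is a 1.7-fold lower number from compound 3 to compound 4 (0.22 log units; within the scatter). For compound 4 the estimated value is 45 nM, with an expected range of 14 nM to 150 nM.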

Compound 4, half-maximal inhibitory concentration: 212 nM
Compound 4: middle estimate off by 4.7-fold (0.67 log units), on the low side; measured number outside the range, above it.
By their numbers in this assay, from the lowest: compound 3; then compounds 1 and 4 (each within the scatter of the next); then compound 2.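

In this assay the same replacement, fluoro in place of hydrogen on an aromatic carbon, now runs the other way: the earlier step gave a 6.6-fold lower number from compound 2 to compound 3 (0.82 log units; beyond the scatter) and this one gives a 2.8-fold higher number from compound 3 to compound 4 (0.45 log units; beyond the scatter). The replacement therefore has no single direction on this aromatic ring, and on the compounds shown its outcome differs with the place of entry, here ortho to a large group and meta to two fluoro groups. No measurement at hand accounts for this reversal.

From the compounds shown here alone, it remains open whether a fluoro at this place would give a higher number without the other two fluoro groups present, or whether the step holds only in their company. Also open, going by these compounds, is how a chloro, a methoxy or an amine at the same place would compare with fluoro.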